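An Expected Step to Compound 3

A few compounds are considered here, and "the series" means these few. Any claim that something is new, unique, unknown or untested is made for them only; others in the source may bear on it.

Measured in an ADME assay on MT4 cells (Homo sapiens) for cytotoxicity, read by MTT assay, with a stated time of 4 days; on this read-out lower numbers stand for higher toxicity in this test and higher numbers for lower toxicity in this test:
Compound 1 `Cc1ccc(-c2c(C)c(-c3ccc4c(c3)CCO4)c(C(OC(C)(C)C)C(=O)O)c(C)c2NS(C)(=O)=O)cc1C`: 38000 nM
Compound 2 `Cc1ccc(-c2c(C)c(-c3ccc4c(c3C)CCCO4)c(C(OC(C)(C)C)C(=O)O)c(C)c2NS(C)(=O)=O)cc1C`: 24000 nM

Compound 2, at 24000 nM, stands within the scatter of compound 1, so neither can be set apart on these numbers. The next compound is compound 3 `Cc1ccc(-c2c(C)c(-c3ccccc3)c(C(OC(C)(C)C)C(=O)O)c(C)c2NS(C)(=O)=O)cc1C`, and its difference from compound 2 is a group of 6 heavy atoms (6 carbon; one six-membered aromatic ring of carbon only) in place of a group of 11 heavy atoms (10 carbon, 1 oxygen; one six-membered non-aromatic ring with 1 hetero atom, one six-membered aromatic ring of carbon only), on an aromatic carbon. Phenyl enters on an aromatic carbon, para to a methanesulfonamido group. Among the compounds with values here, one measured step bears on this, as it changed the group on that same aromatic carbon: a 1.6-fold lower number from compound 1 to compound 2 (0.20 log units; within the scatter). Within the data shown here, that step stayed within the scatter, but no measured compound yet shows the non-aromatic ring removed altogether. On the evidence of that single step, no change beyond the scatter is expected in this assay. The expected step is a 1.3-fold higher number from compound 2 to compound 3 (0.12 log units; within the scatter). For compound 3 the estimated value is 32000 nM, with an expected range of 15000 nM to 70000 nM.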

Compound 3, half-maximal cytotoxic concentration: > 50000 nM
Compound 3: no number, only a limit; the forecaster's own chance of this, stated with the estimate: 10%; middle value at least 1.5-fold (0.19 log units) from the limit.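

With phenyl on the aromatic carbon para to the methanesulfonamido group, the position gives its first change beyond the scatter, seen in this assay as an at least 2.0-fold higher number from compound 2 to compound 3 (0.31 log units; beyond the scatter). Against the smaller group of compound 1, the same phenyl gives an at least 1.3-fold higher number from compound 1 to compound 3 (0.11 log units; that floor lies within the scatter), and the floor of that step lies within the scatter, so this comparison shows no firm change. Compound 3 has only a limit in this assay, not a number: the limit of > 50000 nM in this assay, at which 1 of the 3 values shown sits.

The compounds shown leave open how far the number of compound 3 lies past that limit, and whether the oxygen or the non-aromatic ring as a whole accounts for the step from the larger group to phenyl. They also leave open how the number would respond to an amine or a carboxylic acid on the phenyl, or to a longer alkyl chain in its place.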